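Working notes: aryl ether to aryl ketone on the saturated ring

The source may report more compounds than this note shows. Statements on the series, on what has been measured and on what is new or still open speak of the compounds shown alone.

Two compounds of this series carry numbers in an assay on isolated protein for binding affinity to 5-hydroxytryptamine receptor 7 (Homo sapiens); on this read-out higher numbers stand for weaker inhibition and lower numbers for stronger inhibition. Compound 1 `O=C1c2ccccc2CCCC1CCN1CCC(Oc2ccccc2)CC1` gives 25.1 nM. Compound 2 `O=C1c2ccccc2CCCN1CCN1CCC(Oc2ccc(F)cc2)CC1` gives 4.47 nM, the lowest of the two numbers; the gap from compound 2 to compound 1 lies beyond the scatter. Compound 1 and compound 2 differ in more than one place, so their two values cannot be tied to a single change.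

Compound 3 `O=C(c1ccc(Cl)cc1)C1CCN(CCN2CCCc3ccccc3C2=O)CC1` has not yet been measured in this assay. It follows from compound 2 by one change: (4-chlorophenyl)carbonyl in place of 4-fluorophenoxy on a saturated ring carbon. Among the compounds with values here, no measured pair shows an exchange of this kind, so no step from the data supports a direction. A link through a carbonyl in place of the ether oxygen is a larger alteration than the swap of one halogen, and a small move toward a higher number, possibly still within the scatter, is expected rather than a gain. Compound 3 is expected to give about 10 nM in this assay, with a range from 2.5 nM to 45 nM. The step this estimate means is expected to be a 2.2-fold higher number from compound 2 to compound 3 (0.35 log units; beyond the scatter).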

Compound 3, inhibition constant: 2.51 nM
Estimate against measurement, compound 3: 4.0-fold (0.60 log units) above, within the range that was stated.
By their numbers in this assay, from the lowest: compounds 3 and 2 (each within the scatter of the next); then compound 1.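

Working notes, continued: in this assay the exchange of 4-fluorophenoxy for (4-chlorophenyl)carbonyl on a saturated ring carbon, three ring bonds from the ring nitrogen, gives a 1.8-fold lower number from compound 2 to compound 3 (0.25 log units; within the scatter) and is the only single-place step in the series that can be read. This read-out therefore does not tell the two groups apart, although the link through oxygen gives way to a link through a carbonyl and the halogen changes in the same step. Nothing measured bears on why the two groups read alike.

Within the data shown here, the single step leaves open what the link and the halogen each contribute, and 4-chlorophenoxy or (4-fluorophenyl)carbonyl on the same ring carbon would separate the two. Also open, on these data alone, is how far this tolerance extends in this assay to groups that hold no aromatic ring, such as an amine or a carboxylic acid, or to a longer chain linking the aromatic ring to the saturated ring carbon.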